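The compounds below may be only part of what the source reports. "The series", "measured", "known", "first", "only" and "open" are said of these compounds alone.

Measured compounds in a functional assay on MCF7 cells (Homo sapiens) for cytotoxicity, read by MTT assay, with a stated time of 72 h, tested at 30 uM; a higher number here means more inhibition of growth at the concentration tested, a lower number less inhibition of growth:
compound 1 `N/C(=N\NC(=S)N1CCOCC1)c1ccccn1`, compound 1 gives 78.1%
compound 2 `Cc1cccc(/C(N)=N/NC(=S)N2CCSCC2)n1`, compound 2 gives 38.6%
compound 3 `N/C(=N\NC(=S)N1CCSCC1)c1ccccn1`, compound 3 gives 72.6%

Compound 3 stands second highest of the three numbers. Its nearest neighbour is compound 1, with a number 5.5 percentage points lower from compound 1 to compound 3 (within the scatter), a gap within the scatter. Its furthest is compound 2, with a number 34 percentage points higher from compound 2 to compound 3 (beyond the scatter), a gap beyond the scatter.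

Compound 4 `N/C(=N\NC(=S)N1CCCCC1)c1ccccn1` is not yet measured. It differs from compound 3 by piperidin-1-yl in place of thiomorpholin-4-yl on a thiocarbonyl carbon. For the measured compounds named here, the only measured step at the same place is the one from compound 1 to compound 3, where one ring hetero atom was exchanged for another and the number moved by a number 5.5 percentage points lower from compound 1 to compound 3 (within the scatter), inside the scatter. The step from compound 2 to compound 3 concerns a different place and does not bear on this change. On that basis no step beyond the scatter is expected here; the estimated step is a number 1.6 percentage points lower from compound 3 to compound 4 (within the scatter). For compound 4 in this assay the expected value is 71%, with a range from 56% to 84%.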

Compound 4, percent growth inhibition at one concentration: 69.3%
For compound 4 the middle estimate is 1.7 percentage points above the measured one, and the stated range covers the measured number.
By their numbers in this assay, from the lowest: compound 2; then compounds 4, 3 and 1 (each within the scatter of the next).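

In this assay, the second ring hetero atom on the thiocarbonyl carbon can be absent without a change beyond the scatter: piperidin-1-yl replacing thiomorpholin-4-yl gives a number 3.3 percentage points lower from compound 3 to compound 4 (within the scatter) and piperidin-1-yl replacing morpholin-4-yl gives a number 8.8 percentage points lower from compound 1 to compound 4 (within the scatter) in this series. The earlier step at this place only exchanged one ring hetero atom for another, whereas compound 1, compound 3 and compound 4 now show that oxygen, sulfur or a ring carbon at that ring position can all be accommodated within the scatter. No supporting data bear on why these numbers stay together.

The compounds shown leave open whether a ring is needed here at all, as an open-chain dimethylamino group or a piperazin-1-yl ring carrying a second nitrogen would test. They also leave open whether methyl on the aromatic carbon has a similar effect with piperidin-1-yl as it does with thiomorpholin-4-yl.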